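Working notes: replacing the group on the sulfonyl sulfur

The source may report more compounds than this note shows. Statements on the series, on what has been measured and on what is new or still open speak of the compounds shown alone.

- compound 1 `CNC(=O)c1cc(S(=O)(=O)N2CCS[C@H]2C(=O)O[C@@H](Cc2c(Cl)c[n+]([O-])cc2Cl)c2ccc(OC(F)F)c(OCC3CC3)c2)cn1C` at 63.5%
- compound 2 `Cn1cnc(S(=O)(=O)N2CCS[C@H]2C(=O)O[C@@H](Cc2c(Cl)c[n+]([O-])cc2Cl)c2ccc(OC(F)F)c(OCC3CC3)c2)c1` at 77.7%

In an ADME assay on S9 fraction from lung (Homo sapiens) for metabolic stability, read by LC-MS, using NADPH, with a stated time of 60 min, tested at 1 uM (a lower number here means that less of the compound is left, a higher number that more of the compound is left), compound 2 (77.7%) holds the higher of the two numbers. Compound 3 `COc1ccc(S(=O)(=O)N2CCS[C@H]2C(=O)O[C@@H](Cc2c(Cl)c[n+]([O-])cc2Cl)c2ccc(OC(F)F)c(OCC3CC3)c2)cc1OC` has not yet been measured. It differs from compound 2 by one change, (3,4-dimethoxyphenyl in place of 1-methyl-1H-imidazol-4-yl on a sulfonyl sulfur), with 3,4-dimethoxyphenyl in place of 1-methyl-1H-imidazol-4-yl on a sulfonyl sulfur.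

Going by the values given here, only one measured step bears on this: a number 14.2 percentage points higher from compound 1 to compound 2 (beyond the scatter), a modest move beyond the scatter at the same place. Among the compounds with values here, no measured compound carries 3,4-dimethoxyphenyl, so the support is thin. Within the data shown here, compound 1 (63.5%) is the only comparison with a group of the same heavy-atom count as 3,4-dimethoxyphenyl, although its ring differs. On that basis a fall of similar size is expected, with low confidence. The expected step is a number 12.7 percentage points lower from compound 2 to compound 3 (beyond the scatter), and a result within the scatter of compound 2 would not be surprising. Compound 3 is estimated at 65% (expected range 45% to 84%).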

Compound 3, percent of the compound remaining: 50.7%
The estimate for compound 3 lay 14.3 percentage points above the measured number; low and high end bracket the measured number.
By their numbers in this assay, from the lowest: compound 3; then compound 1; then compound 2.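

In this assay, the group on the sulfonyl sulfur now gives three separate readings, and the change to 3,4-dimethoxyphenyl produces a number 27 percentage points lower from compound 2 to compound 3 (beyond the scatter) as the larger of the two steps away from the 1-methyl-1H-imidazol-4-yl compound. Heavy-atom count does not settle the number at this place: the groups in compound 1 and compound 3 both have 10 heavy atoms, yet the change in atom types and ring gives a number 12.8 percentage points lower from compound 1 to compound 3 (beyond the scatter) and so goes against any simple ordering by group size. Among these three compounds, the carbon-only six-membered ring carrying two methoxy groups goes with the lowest number, but no measurement available here explains why the number moves with these groups.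

From the compounds shown here alone, it remains open whether the lower number in compound 3 goes with the carbon-only ring itself or with its two methoxy groups, a question that an unsubstituted phenyl or a 4-methoxyphenyl on the same sulfonyl sulfur would address. Going by these compounds, it also remains open whether another five-membered ring, such as 1-methyl-1H-pyrazol-4-yl, would read close to compound 2 or whether the 1-methyl-1H-imidazol-4-yl group is unusual in this short series.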